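This account rests on a few compounds, and the source may have more. Where it says the series, first, only, none or still open, it means among the compounds named here.

Working notes on the series. In a functional assay on SMMC-7721 cells (Homo sapiens) for cytotoxicity, read by MTT assay, with a stated time of 24 h (on this read-out lower numbers stand for stronger inhibition and higher numbers for weaker inhibition), compound 1 `O=C1/C(=C/c2ccncc2)CN(S(=O)(=O)c2ccc([N+](=O)[O-])cc2)C/C1=C\c1ccccc1F` gives 15800 nM, compound 2 `O=C1/C(=C/c2ccncc2)CN(S(=O)(=O)c2ccc(C(F)(F)F)cc2)C/C1=C\c1ccccc1F` gives 11100 nM and compound 3 `O=C1/C(=C/c2ccncc2)CN(S(=O)(=O)c2ccc(Br)cc2)C/C1=C\c1ccccc1F` gives 12600 nM. Compound 2 therefore stands with the other two, and the three values lie within the scatter of one another. Compound 4 `O=C1/C(=C/c2ccncc2)CN(S(=O)(=O)c2ccc(C(F)(F)F)cc2)C/C1=C\c1ccccc1C(F)(F)F` has trifluoromethyl in place of fluoro on an aromatic carbon, ortho to a large group: trifluoromethyl in place of fluoro on an aromatic carbon. Going by the values given here, no measured step touches the 2-fluorophenyl group, so the available evidence is indirect. Among the compounds with values here, the closest precedent is a 1.4-fold lower number from compound 1 to compound 2 (0.15 log units; within the scatter), where trifluoromethyl enters at another place in the molecule. The other two steps are a 1.3-fold lower number from compound 1 to compound 3 (0.10 log units; within the scatter) and a 1.1-fold higher number from compound 2 to compound 3 (0.06 log units; within the scatter). All three are small, but they cannot show how the new change will behave at its own place. No step beyond the scatter is expected in this assay, and neither direction is favoured. The estimated step is a 1.0-fold lower number from compound 2 to compound 4 (0.00 log units; within the scatter). Compound 4 is expected at about 11000 nM, with an estimated range of 5000 nM to 24000 nM.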

Compound 4, half-maximal inhibitory concentration: 3840 nM
Compound 4: the middle estimate sits 2.9-fold (0.46 log units) above what was measured; the measured number lies below the stated range.
By their numbers in this assay, from the lowest: compound 4; then compounds 2, 3 and 1 (each within the scatter of the next).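

In this assay, going by these compounds alone, the change from 2-fluorophenyl to 2-(trifluoromethyl)phenyl gives a 2.9-fold lower number from compound 2 to compound 4 (0.46 log units; beyond the scatter), the only step that lies beyond the scatter. This position therefore responds to a substitution, whereas the three earlier steps, all at the other substituted aromatic ring, stayed within the scatter. Trifluoromethyl entering in place of nitro at that other place gives only a 1.4-fold lower number from compound 1 to compound 2 (0.15 log units; within the scatter), so the small step there says little about this position, and nothing measured here explains the difference.

Among the compounds shown, only fluoro and trifluoromethyl stand at this position, so how a methoxy group, an amine or a carboxylic acid would read there remains open. Also open is whether the step holds with nitro or bromo at the other place, since it is shown only with trifluoromethyl there.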